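The compounds below may be only part of what the source reports. "The series", "measured", "known", "first", "only" and "open" are said of these compounds alone.

Compound 2 `CCOc1ncc(-c2nc(C(F)(F)F)sc2N2CCN(C(=O)Cn3nc(C)nc3C)[C@H](C)C2)cn1` gives 364 nM in an assay on blood for inhibition of C-X-C chemokine receptor type 3 (Homo sapiens), with a stated time of 30 min (on this read-out lower numbers stand for stronger inhibition and higher numbers for weaker inhibition), the second highest of the three numbers shown. Compound 3 `CCOc1ncc(-c2nc(C(F)(F)F)sc2N2CCN(C(=O)Cn3cnc(C(F)(F)F)n3)[C@H](C)C2)cn1` gives 524 nM, and a 1.4-fold higher number from compound 2 to compound 3 (0.16 log units; within the scatter). Compound 1 `CCOc1ncc(-c2nc(C(F)(F)F)sc2N2CCN(C(=O)Cn3ccc4cccnc43)[C@H](C)C2)cn1` gives 47 nM, and a 7.7-fold higher number from compound 1 to compound 2 (0.89 log units; beyond the scatter). Compound 4 `Cc1nc(C)n(CC(=O)N2CCN(c3sc(C(F)(F)F)nc3-c3cnc(OC(C)C)nc3)C[C@H]2C)n1` differs from compound 2 by methyl in place of hydrogen on a saturated chain carbon bound to an oxygen on an aromatic ring and a saturated chain carbon; cut one bond further out, this reads ethoxy to isopropoxy. Every measured step — a 7.7-fold higher number from compound 1 to compound 2 (0.89 log units; beyond the scatter), an 11-fold higher number from compound 1 to compound 3 (1.05 log units; beyond the scatter) and a 1.4-fold higher number from compound 2 to compound 3 (0.16 log units; within the scatter) — exchanges the aromatic group on the saturated chain carbon bound to the carbonyl carbon, a different place on the shared core, so none of them bears on this change. With no shown step at the ethoxy group, no step beyond the scatter is expected in this assay. Compound 4 is therefore estimated at 360 nM, with a range of 150 nM to 900 nM, which means a 1.0-fold lower number from compound 2 to compound 4 (0.00 log units; within the scatter).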

Compound 4, half-maximal inhibitory concentration: 216 nM
Estimate against measurement, compound 4: 1.7-fold (0.22 log units) above; the range from low to high includes it.
By their numbers in this assay, from the lowest: compound 1; then compounds 4, 2 and 3 (each within the scatter of the next, the first and the last beyond it).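

In this assay, among these compounds, ethoxy to isopropoxy gives a 1.7-fold lower number from compound 2 to compound 4 (0.23 log units; within the scatter) as the first reading at this position, so the extra methyl on the saturated chain carbon bound to the oxygen leaves the number within the scatter with 3,5-dimethyl-1H-1,2,4-triazol-1-yl on the other side of the shared core. Nothing measured here bears on a cause for this step.

On these data alone, whether the same exchange reads alike with the groups of compound 1 and compound 3 stays open. Also open, as far as these compounds go, is how a longer chain such as n-butoxy, or an amine, would read in place of ethoxy.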